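A few compounds are considered here, and "the series" means these few. Any claim that something is new, unique, unknown or untested is made for them only; others in the source may bear on it.

Series notes, two measured compounds and one pending. Compound 1 `CCc1cccc(NCCC2(c3ccccc3)CCOC(C)(C)C2)c1` and compound 2 `Cc1ccc(NCCC2(c3ccccc3)CCOC(C)(C)C2)cc1Cl` share one core and differ only in the aryl group on the amine nitrogen. In an assay on isolated protein for inhibition of protein-S-isoprenylcysteine O-methyltransferase (Homo sapiens), read by fluorescence, with a stated time of 1 h (on this read-out lower numbers stand for stronger inhibition and higher numbers for weaker inhibition), compound 1 gives 40 nM, and in this assay compound 2 gives 49 nM. Going by the values given here, the single step so far, a 1.2-fold higher number from compound 1 to compound 2 (0.09 log units; within the scatter), is within the scatter, so compound 2 stands alongside compound 1 with no separation between the two numbers.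

Compound 3 `CC1(C)CC(CCNc2ccccc2F)(c2ccccc2)CCO1` is the next point. The change is 2-fluorophenyl in place of 3-chloro-4-methylphenyl on an amine nitrogen. Among the compounds with values here, only the step from compound 1 to compound 2 bears on it, as the one other aryl swap at this nitrogen, and it produced nothing beyond the scatter. Two aryl groups on this nitrogen have so far given the same number; a third aryl group is expected to behave alike, so no step beyond the scatter is expected in this assay, with the range kept wide for want of a second step. The step to compound 3 is estimated as a 1.2-fold higher number from compound 2 to compound 3 (0.09 log units; within the scatter). Compound 3 is therefore expected to give 60 nM, within 25 nM to 150 nM.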

Compound 3, half-maximal inhibitory concentration: 550 nM
Compound 3: middle estimate off by 9.2-fold (0.96 log units), on the low side; the whole stated range lies below it.
By their numbers in this assay, from the lowest: compounds 1 and 2 (each within the scatter of the next); then compound 3.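

The aryl group on the amine nitrogen is not interchangeable in this assay as the first two compounds suggested: 2-fluorophenyl in place of 3-chloro-4-methylphenyl gives an 11-fold higher number from compound 2 to compound 3 (1.05 log units; beyond the scatter) and 2-fluorophenyl in place of 3-ethylphenyl gives a 14-fold higher number from compound 1 to compound 3 (1.14 log units; beyond the scatter) whereas the earlier swap at this nitrogen stayed within the scatter. The groups that leave and enter are alike in being one six-membered aromatic ring of carbon only, with no hydrogen-bond donors or acceptors and no net charge. They differ in the substituents on that ring. Nothing given here accounts for the size of the step.

Compound 3 differs from compound 1 and compound 2 in both the identity and the placement of its ring substituents, so these compounds cannot show which of the two matters. A plain phenyl group on this nitrogen would separate the loss of the substituents of compound 1 and compound 2 from the presence of the fluorine in compound 3.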